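Fluoro for methyl on the urea aryl ring

The compounds below may be only part of what the source reports. "The series", "measured", "known", "first", "only" and "open" are said of these compounds alone.

Compound 3 `COc1cc2ncnc(NCc3cccc(NC(=O)Nc4ccccc4C)c3)c2cc1OC` sits at the ceiling of a functional assay on HepG2 cells (Homo sapiens) for antiproliferative activity, read by MTT assay; on this read-out higher numbers stand for weaker inhibition and lower numbers for stronger inhibition: in this assay compound 3 gives > 50000 nM, which is a limit and not a number. Compound 4 `COc1cc2ncnc(NCc3cccc(NC(=O)Nc4ccccc4F)c3)c2cc1OC` differs from it by fluoro in place of methyl on an aromatic carbon. One measured step is of a related kind, an at least 1.2-fold lower number from compound 1 to compound 2 (0.09 log units; that floor lies within the scatter). In this assay compound 1 `Cc1cccc(NC(=O)Nc2cccc(CNc3ncnc4ccccc34)c2)c1` gives > 50000 nM, likewise a limit. Compound 2 `O=C(Nc1cccc(CNc2ncnc3ccccc23)c1)Nc1cccc(C(F)(F)F)c1` gives 40000 nM in this assay. Because (the limit of > 50000 nM in this assay, at which 2 of the 3 values shown sit), that measured step carries only a floor, and a one-atom exchange on the same ring is expected to move the read-out by no more than the scatter. Compound 4 is therefore expected near 50000 nM (range 25000 nM to 100000 nM), an expected step of a number no higher from compound 3 to compound 4 (the limit leaves the size open), most likely again reported as a limit.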

Compound 4, half-maximal inhibitory concentration: 24900 nM
Compound 4: the middle estimate sits 2.0-fold (0.30 log units) above what was measured, and the stated range ends above it.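

The exchange of 2-methylphenyl for 2-fluorophenyl shows an at least 2.0-fold lower number from compound 3 to compound 4 (0.30 log units; that floor lies within the scatter) in this assay and so gives a number, not a limit, at this place on the urea aryl ring. For the compounds shown here, this is the first one-atom exchange at this place to end on a number. From the compounds shown here alone, its true size stays open, since the step starts from a limit: the limit of > 50000 nM in this assay, at which 2 of the 4 values shown sit.

Going by these compounds, whether chloro, methoxy or an amine at the same place would give a lower number stays open. So does whether fluoro behaves alike on the core of compound 1.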